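The compounds below may be only part of what the source reports. "The series", "measured", "known", "first", "only" and "open" are said of these compounds alone.

Working notes on a series built on one shared core, all read in a functional assay on the whole organism with Rattus norvegicus as the target, at a dose of 100 mg/kg; a lower number here means less inhibition, a higher number more inhibition at the dose given (going by the name of the read-out). Compound 1 `C/N=C(\S)NCCCCCn1nc(-c2ccccc2)ccc1=O` gives 68.9%. Compound 2 `CC/N=C(/NC#N)NCCCn1nc(-c2ccccc2)ccc1=O` gives 62.9%. Compound 3 `N/C(S)=N/CCCCn1nc(-c2ccccc2)ccc1=O` gives 72%, the highest of the three numbers, yet its gap to each of the other two lies within the scatter, so no order among the three can be read. The measured steps are all small: a number 6 percentage points lower from compound 1 to compound 2 (within the scatter), and a number 3.1 percentage points higher from compound 1 to compound 3 (within the scatter), and a number 9.1 percentage points higher from compound 2 to compound 3 (within the scatter). Compound 4 `CC/N=C(\S)NCCCn1nc(-c2ccccc2)ccc1=O` has not yet been measured. Against compound 3 it carries a group of 6 heavy atoms (3 carbon, 2 nitrogen, 1 sulfur; no ring) in place of a group of 5 heavy atoms (2 carbon, 2 nitrogen, 1 sulfur; no ring), on a saturated chain carbon, three bonds along the chain from an aromatic nitrogen. Within the data shown here, the nearest precedent is the step that swapped a group of 6 heavy atoms (3 carbon, 2 nitrogen, 1 sulfur) for a smaller one on the chain, which ran within the scatter, as did the second step touching the group on a saturated chain carbon, three bonds along the chain from an aromatic nitrogen. Among the measured compounds shown here, nothing measured so far suggests that enlarging this group shifts inhibition beyond the scatter. Compound 4 is therefore expected to give 70% in this assay, with a range from 60% to 80%. The estimated step, a number 2 percentage points lower from compound 3 to compound 4 (within the scatter), is expected to stay within the scatter.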

Compound 4, a percentage reported as inhibition, in the whole organism at one dose (the size of the read-out at that dose, not a potency): 39%
The estimate for compound 4 lay 31 percentage points above the measured number; measured number outside the range, below it.
By their numbers in this assay, from the lowest: compound 4; then compounds 2, 1 and 3 (each within the scatter of the next).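

In this assay, among these compounds, this position proves sensitive for the first time: putting the group of 6 heavy atoms (3 carbon, 2 nitrogen, 1 sulfur) in place of the group of 5 heavy atoms (2 carbon, 2 nitrogen, 1 sulfur), on a saturated chain carbon, three bonds along the chain from an aromatic nitrogen, gives a number 33 percentage points lower from compound 3 to compound 4 (beyond the scatter) as the first step to leave the scatter. Compound 4 also stands apart from the other two compounds, with a number 23.9 percentage points lower from compound 2 to compound 4 (beyond the scatter) and with a number 29.9 percentage points lower from compound 1 to compound 4 (beyond the scatter) on the two remaining steps, so it is the lowest of the four, while the steps among the earlier three all stayed within the scatter. The two exchanged groups match in double bonds, hydrogen-bond donors, hydrogen-bond acceptors and net charge as counted, and differ in their carbon count, so a change that leaves those counts untouched is enough for a large step here.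

The compounds shown leave open whether a longer chain, or an amine or a carboxylic acid in place of the exchanged group, would keep the number low or restore it. No measurement on hand speaks to what lies behind this step.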